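Hydroxy returned to the seven-membered ring: compound 3

The source may hold more compounds than are shown below. What is called first, only, known or untested is meant among the compounds shown, and "the series" means these compounds.

In a functional assay on MCF7 cells (Homo sapiens) for cytotoxicity, read by colorimetric assay and neutral red uptake, with a stated time of 72 h (a lower number here means a stronger inhibitor, a higher number a weaker inhibitor), compound 2 `CO[C@@H](C(=O)N[C@@H]1CCCCNC1=O)[C@H](O)[C@@H](O)[C@H](O)/C=C/C(C)(C)C` gives the lowest of the two numbers seen so far, with 200 nM. Compound 1 `CO[C@@H](C(=O)N[C@@H]1CC[C@H](O)CNC1=O)[C@H](O)[C@@H](O)[C@H](O)/C=C/C(C)(C)C` gives 80400 nM in this assay; the step of a 400-fold lower number from compound 1 to compound 2 (2.60 log units; beyond the scatter) corresponds to hydrogen in place of hydroxy on a saturated ring carbon. For the measured compounds named here, compound 3 `CO[C@@H](C(=O)N[C@@H]1CC[C@@H](O)CNC1=O)[C@H](O)[C@@H](O)[C@H](O)/C=C/C(C)(C)C` moves the other way: hydroxy in place of hydrogen on a saturated ring carbon The hydroxy of compound 3 sits on the same saturated ring carbon as that of compound 1 but in the opposite configuration, so the one step that bears on it, a 400-fold lower number from compound 1 to compound 2 (2.60 log units; beyond the scatter), is read in reverse and only as a rough guide. A large rise in the number is therefore expected for compound 3, although the size need not match the step already seen. The expected step is a 100-fold higher number from compound 2 to compound 3 (2.00 log units; beyond the scatter). Compound 3 is estimated at 20000 nM, with a range from 2000 nM to 100000 nM.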

Compound 3, half-maximal inhibitory concentration: 165000 nM
Beside the measured number, compound 3's estimate is 8.3-fold (0.92 log units) below it; the measured number lies above the stated range.
By their numbers in this assay, from the lowest: compound 2; then compound 1; then compound 3.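

In this assay, the high number seen with compound 1 is not tied to one configuration of the hydroxy: with the opposite configuration the step is still large, an 830-fold higher number from compound 2 to compound 3 (2.92 log units; beyond the scatter), so on these compounds hydroxy on this saturated ring carbon gives a much higher number in either configuration. Configuration matters far less than the presence of the hydroxy, with a 2.1-fold higher number from compound 1 to compound 3 (0.31 log units; beyond the scatter), a modest step though still beyond the scatter. That modest step can be assigned to this single stereocentre: the fact that compounds 1 and 3 differ only in the configuration as drawn.

Going by these compounds, whether the rise follows the hydroxy specifically or any substituent at this position remains open, and a methoxy, an amine or a fluorine there would separate the two readings. Also open, on these data alone, is how hydroxy behaves on the other saturated carbons of the seven-membered ring.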